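Fluoropyridine swap from compound 2 to compound 3

The source may report more compounds than this note shows. Statements on the series, on what has been measured and on what is new or still open speak of the compounds shown alone.

In an ADME assay on MRC5 cells (Homo sapiens) for cytotoxicity, read by fluorescence, with a stated time of 72 h (a lower number here means a stronger inhibitor, a higher number a weaker inhibitor), compound 1 `CC1(COc2ccc(C(F)(F)F)cn2)Cn2cc([N+](=O)[O-])nc2O1` gives > 64000 nM as a limit of the assay and not a number. Compound 2 `CC1(COc2ccc(-c3ccc(F)cn3)cn2)Cn2cc([N+](=O)[O-])nc2O1` gives > 64000 nM as a limit too. Among the compounds with values here, the one measured step is a step that the two limits leave unreadable from compound 1 to compound 2 and offers no size to carry forward. Within the data shown here, the only guide is the limit of > 64000 nM in this assay, at which 2 of the 2 values shown sit, and no lower value has been seen. Compound 3 `CC1(COc2ccc(-c3ccc(F)nc3)cn2)Cn2cc([N+](=O)[O-])nc2O1` has 6-fluoropyridin-3-yl in place of 5-fluoropyridin-2-yl on an aromatic carbon with the same atoms joined differently. In this assay the estimated a number no higher from compound 2 to compound 3 (the limit leaves the size open) is expected to stay within the scatter. For compound 3 the estimate is 64000 nM (expected range 30000 nM to 64000 nM) and a limit is the likeliest report.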

Compound 3, half-maximal inhibitory concentration in the MRC5 assay: > 64000 nM
Compound 3: a limit, no number (the forecaster's own chance of this, stated with the estimate: 85%); the middle value lies on the limit itself.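

Within the data shown here, compound 1, compound 2 and compound 3 all give limits, not numbers, in the MRC5 assay, and no step among them can be read: the limit of > 64000 nM in the MRC5 assay, at which 3 of the 3 values shown sit. The compounds shown leave open whether any group on this aromatic carbon gives a number in the MRC5 assay. In a physicochemical assay for solubility, read by HPLC, measured as kinetic solubility, at 20 degrees C, at pH 1 (on this read-out higher numbers stand for higher solubility and lower numbers for lower solubility), compound 2 gives 46 ug/mL and compound 3 gives 19 ug/mL, a 2.4-fold lower number from compound 2 to compound 3 (0.38 log units; beyond the scatter).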